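The source may hold more compounds than are shown below. What is called first, only, known or untested is meant among the compounds shown, and "the series" means these compounds.

Measured so far in an assay on MDA-MB-231 cells for binding affinity to C-X-C chemokine receptor type 4 (Homo sapiens), read by fluorescence and microscopy, with stated times of 10 min and 30 min; a lower number here means that less compound is needed, a higher number that more compound is needed for the effect:
- compound 1, `O=C(NCc1ccc(CNS(=O)(=O)c2cccnc2)cc1)c1ccc(F)cc1`: 1000 nM
- compound 2, `Cc1ccc(S(=O)(=O)NCc2ccc(CNC(=O)c3ccc(F)nc3)cc2)cc1`: a limit of the assay, > 1000 nM

Going by the values given here, compound 1 is the only member of the pair with an actual number in this assay. For compound 2 the result in this assay is recorded as a limit of the assay only, > 1000 nM, so no comparison of the two can be drawn beyond that one sits at the limit of > 1000 nM in this assay, at which 1 of the 2 values shown sits, while the other does not. Among the compounds with values here, no step between measured compounds is available to rest a forecast on.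

Compound 3, `O=C(NCc1ccc(CNS(=O)(=O)c2ccc(F)c(F)c2)cc1)c1ccc(F)cc1`, differs from compound 1 in one place: 3,4-difluorophenyl in place of pyridin-3-yl on a sulfonyl sulfur. With no measured step of this kind in the set, the expected step from compound 1 to compound 3 is put at roughly none beyond the usual scatter, a 1.3-fold lower number from compound 1 to compound 3 (0.10 log units; within the scatter). Compound 3 is therefore estimated at 800 nM in this assay, with a range from 300 nM to 3000 nM.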

Compound 3, effective concentration (reported as EC, without a stated level of effect): 10 nM
Estimate against measurement, compound 3: 80-fold (1.90 log units) above; measured number below the stated range.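

In this assay the group on the sulfonyl sulfur proves to be a sensitive position: 3,4-difluorophenyl in place of pyridin-3-yl gives a 100-fold lower number from compound 1 to compound 3 (2.00 log units; beyond the scatter) with the rest of the structure unchanged. Going by these compounds alone, this is the first step that can be read at a single place, and it shows that a change of this one aromatic ring alone can move the number by a large amount. Nothing measured here separates the part played by the fluorine atoms from that of the lost ring nitrogen, so no cause can be given for the step.

Still open, on these data alone, is how plain phenyl, a phenyl carrying a single fluorine or a methoxy group, or a simple alkyl chain would read on the sulfonyl sulfur. Also open, as far as these compounds go, is whether the same step holds when the fluorinated amide end of the shared core is replaced.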